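Replacing ethyl with 2,6-dichlorophenyl on the shared core

A few compounds are considered here, and "the series" means these few. Any claim that something is new, unique, unknown or untested is made for them only; others in the source may bear on it.

- compound 1 `CC(=O)Nc1ncc(SCc2ncc(C(C)(C)C)o2)s1` gives 50 nM
- compound 2 `CC(C)(C)C(=O)Nc1ncc(SCc2ncc(C(C)(C)C)o2)s1` gives 250 nM
- compound 3 `CCNC(=O)Nc1ncc(SCc2ncc(C(C)(C)C)o2)s1` gives 120 nM

In a functional assay on A2780 cells (Homo sapiens) for cytotoxicity (a lower number here means a stronger inhibitor, a higher number a weaker inhibitor), compound 3 holds the middle place of the three numbers, above compound 1 and under compound 2. Compound 4 `CC(C)(C)c1cnc(CSc2cnc(NC(=O)Nc3c(Cl)cccc3Cl)s2)o1` keeps the shared core of compound 3 and differs by 2,6-dichlorophenyl in place of ethyl on an amide-type nitrogen with 2,6-dichlorophenyl in place of ethyl on an amide-type nitrogen. Among the compounds with values here, no measured step places a ring at this nitrogen, so the evidence is indirect. The nearest guides are changes on the carbonyl carbon. The step of a 5.0-fold higher number from compound 1 to compound 2 (0.70 log units; beyond the scatter) and the step of a 2.4-fold higher number from compound 1 to compound 3 (0.38 log units; beyond the scatter) were both modest, and both raised the number when methyl was replaced. The step of a 2.1-fold lower number from compound 2 to compound 3 (0.32 log units; beyond the scatter) was also modest. On this basis a modest rise is expected, with wide uncertainty. The expected change is a 1.7-fold higher number from compound 3 to compound 4 (0.22 log units; within the scatter) as an estimate only. For this assay compound 4 is estimated at 200 nM with an expected range from 50 nM to 800 nM before any measurement.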

Compound 4, half-maximal inhibitory concentration: 1500 nM
Estimate against measurement, compound 4: 7.5-fold (0.88 log units) below, and the stated range ends below it.
By their numbers in this assay, from the lowest: compound 1; then compound 3; then compound 2; then compound 4.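

In this assay, within the data shown here, the amide-type nitrogen proved far less tolerant than the earlier compounds suggested: with 2,6-dichlorophenyl in place of ethyl there is a 13-fold higher number from compound 3 to compound 4 (1.10 log units; beyond the scatter), a large step, whereas every step among the first three compounds was modest. The new compound also sits clearly above both remaining compounds, with a 6.0-fold higher number from compound 2 to compound 4 (0.78 log units; beyond the scatter) and a 30-fold higher number from compound 1 to compound 4 (1.48 log units; beyond the scatter), which makes it the weakest of the four in this series. So a ring-bearing group on this nitrogen is the one change shown here that moves the number by a large margin rather than a modest one.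

The compounds shown leave open whether an unsubstituted phenyl or a longer chain such as n-butyl on this nitrogen would stay close to compound 3 or fall toward compound 4. Nothing available accounts for the size of this loss.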